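This account rests on a few compounds, and the source may have more. Where it says the series, first, only, none or still open, it means among the compounds named here.

Measured compounds in a functional assay on MDA-MB-231 cells (Homo sapiens) for cytotoxicity, read by MTT assay; on this read-out higher numbers stand for weaker inhibition and lower numbers for stronger inhibition:
compound 1, `COc1ccc(-c2cn(-c3ccc(Oc4ccccc4)cc3)nn2)cc1`, gives > 100 nM, which is a limit of the assay.
compound 2, `Nc1ccc(-c2cn(-c3ccc(Oc4ccccc4)cc3)nn2)cc1`, gives > 10000 nM, again a limit.
compound 3, `Oc1cc(O)cc(-c2cn(-c3ccc(Oc4ccccc4)cc3)nn2)c1`, gives > 10000 nM, again a limit.

Compound 2 stands at the limit of > 10000 nM in this assay, at which 2 of the 3 values shown sit, and compound 3 shares that limit. Compound 1 stands at the limit of > 100 nM in this assay, at which 1 of the 3 values shown sits. For the measured compounds named here, no compound in this assay has a measured number; every value is a limit. Of the three steps between measured compounds, a step that the two limits leave unreadable from compound 1 to compound 2, a step that the two limits leave unreadable from compound 1 to compound 3 and a step that the two limits leave unreadable from compound 2 to compound 3 each join two limits, so none of them has a readable size, and none says in which direction it runs.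

Compound 4, `COc1ccc(-n2cc(-c3ccc(N)cc3)nn2)cc1`, differs from compound 2 by methyl in place of phenyl on an oxygen on an aromatic ring. Going by the values given here, all three measured steps change the substituent on the aryl carbon of the other ring, not the group on this oxygen, so no measured step bears on the change from compound 2 to compound 4, and no size or direction can be drawn from them.

What remains is the standing of compound 2 itself at its limit. The estimate for compound 4 therefore rests only on that standing. Compound 4 is expected to sit near 15000 nM, with a range from 4000 nM to 60000 nM. The step this estimate implies is a step that the limit leaves unreadable from compound 2 to compound 4, expected to remain within the scatter, with a high chance that only a limit is reported.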

Compound 4, half-maximal inhibitory concentration: > 100 nM
Compound 4 was reported as a limit; the forecaster's own chance of this, stated with the estimate: 70%; the middle value lies beyond the limit too.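

In this assay compound 4 gives > 100 nM, which is a limit. Compound 2 gives > 10000 nM, also a limit. The step between compound 2 and compound 4 therefore cannot be read. The compounds shown leave open whether phenoxy to methoxy shifts this read-out at all, and in which direction, with no measured number for any compound.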